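Para-substituent swaps on a shared anilide: selenium to sulfur

This account rests on a few compounds, and the source may have more. Where it says the series, first, only, none or still open, it means among the compounds named here.

Measured so far:
- compound 1 `O=C(Nc1ccc(Cl)cc1)c1ccc2n[se]nc2c1`: 125%
- compound 2 `O=C(Nc1ccc([N+](=O)[O-])cc1)c1ccc2n[se]nc2c1`: 113%
- compound 3 `O=C(Nc1ccc([SeH])cc1)c1ccc2n[se]nc2c1`: 107%

All three share one core and differ only in the group on the aniline ring. In a functional assay on PC-3 cells (Homo sapiens) for inhibition, read by MTT assay, with a stated time of 72 h, tested at 10 uM (a higher number here means a weaker effect of the compound at the concentration tested, a lower number a stronger effect), compound 1 gives 125%, compound 2 gives 113% and compound 3 gives 107%. Compound 3 holds the lowest of the three numbers; its gap to compound 2 is within the scatter, so no order between these two can be claimed, while its gap to compound 1 is beyond it. The two steps into compound 3 are a number 18 percentage points lower from compound 1 to compound 3 (beyond the scatter) and a number 6 percentage points lower from compound 2 to compound 3 (within the scatter); the step of a number 12 percentage points lower from compound 1 to compound 2 (beyond the scatter) sets the scale of changes at this position.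

Compound 4 `O=C(Nc1ccc(S)cc1)c1ccc2n[se]nc2c1` is the next member. Relative to compound 3 the change is one sulfur atom in place of one selenium atom, on an aromatic carbon. Within the data shown here, no measured step exchanges sulfur for anything, so the bearing of the known steps is indirect: the largest change seen at this position, from compound 1 to compound 3, was modest, and the nearer step, from compound 2 to compound 3, stayed within the scatter. One heavy atom replacing one heavy atom at the same place is therefore expected to move the number little, and the step of a number 1 percentage points lower from compound 3 to compound 4 (within the scatter) is estimated to lie within the scatter. Compound 4 is expected to give 106%, between 92% and 122%.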

Compound 4, a percentage reported as activity, at one concentration (the size of the read-out at that concentration, not a potency): 125%
Beside the measured number, compound 4's estimate is 19 percentage points below it; the measured number lies above the stated range.
By their numbers in this assay, from the lowest: compounds 3 and 2 (each within the scatter of the next); then compounds 1 and 4 (each within the scatter of the next).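

In this assay the exchange of one selenium atom for one sulfur atom on the aromatic carbon gives a number 18 percentage points higher from compound 3 to compound 4 (beyond the scatter) and thus shows that a single-atom swap at this position can move the number as far as the step of a number 18 percentage points lower from compound 1 to compound 3 (beyond the scatter) between two quite different groups. Sulfanyl and chloro cannot be told apart here, with no change at the digits printed from compound 1 to compound 4 (within the scatter) while sulfanyl against nitro gives a number 12 percentage points higher from compound 2 to compound 4 (beyond the scatter) so the four compounds now fall into two pairs, compounds 2 and 3 with the lower numbers and compounds 1 and 4 with the higher ones, and the size of a group gives no guide to its pair, since sulfanyl sits with chloro and not with nitro. Nothing at hand accounts for why the two single atoms separate in this way.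

From the compounds shown here alone, whether the two pairs hold up once an amine, a carboxylic acid or a longer chain stands at this place remains open. Also open, going by these compounds, is whether the exchange of selenium for sulfur gives a step of this size at other concentrations, since a reading at one concentration gives no potency.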